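From carboxy to carbamoyl at an assay limit

This account rests on a few compounds, and the source may have more. Where it says the series, first, only, none or still open, it means among the compounds named here.

Measured so far, both values being limits:
- Compound 1 `C=C[C@@](C)(/C=C/c1ccc(O)c(/C=C/C#N)c1)CCC=C(C)C` gives > 49000 nM in a functional assay on Jurkat cells (Homo sapiens) for cytotoxicity, with a stated time of 72 h; on this read-out higher numbers stand for an effect only at larger amounts of compound and lower numbers for an effect already at smaller amounts
- Compound 2 `C=C[C@@](C)(/C=C/c1ccc(O)c(/C=C/C(=O)O)c1)CCC=C(C)C` gives > 49000 nM in this assay

Within the data shown here, compound 2 stands only at a limit in this assay, with > 49000 nM as its sole value, and that is not a number. Both values shown rest on the same limit (the limit of > 49000 nM in this assay, at which 2 of the 2 values shown sit). Compound 3 `C=C[C@@](C)(/C=C/c1ccc(O)c(/C=C/C(N)=O)c1)CCC=C(C)C` changes one group of compound 2, with amino in place of hydroxy on a carbonyl carbon, so carboxy becomes carbamoyl. Among the measured compounds shown here, the one measured step that involves the carboxy group (a step that the two limits leave unreadable from compound 1 to compound 2) has no readable size. No step beyond the scatter is therefore expected in this assay, and no direction can be given. The expected step reads as follows (a number no higher from compound 2 to compound 3 (the limit leaves the size open)). For compound 3 the estimate is 49000 nM (expected range 20000 nM to 80000 nM).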

Compound 3, half-maximal effective concentration: > 49000 nM
Compound 3: a limit, no number; the forecaster's own chance of this, stated with the estimate: 80%; the middle value sits exactly at the limit.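

No step can be read between compound 1, compound 2 and compound 3, because all three stop at one shared limit, which is not a number: the limit of > 49000 nM in this assay, at which 3 of the 3 values shown sit.

The compounds shown leave open how the cyano, carboxy and carbamoyl groups compare in this assay.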